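A few compounds are considered here, and "the series" means these few. Any claim that something is new, unique, unknown or untested is made for them only; others in the source may bear on it.

Working notes on the series, read in an ADME assay on Huh-7 cells (Homo sapiens) for cytotoxicity; on this read-out lower numbers stand for higher toxicity in this test and higher numbers for lower toxicity in this test.

Compound 1 `O=c1cc(CNCc2ccccc2[N+](=O)[O-])oc2ccc(O)c(O)c12` gives 41300 nM. Compound 2 `Cc1ccccc1CNCc1cc(=O)c2c(O)c(O)ccc2o1` gives 52200 nM; the step of a 1.3-fold higher number from compound 1 to compound 2 (0.10 log units; within the scatter) corresponds to the change (methyl in place of nitro on an aromatic carbon). Compound 3 `O=c1cc(CNCc2ccc([N+](=O)[O-])cc2)oc2ccc(O)c(O)c12` gives 73300 nM; its number and that of compound 1 lie within the scatter of each other, and the difference between the two cores is not broken down here beyond the fact that they share the same atoms joined differently. Compound 4 `Cc1ccc(CNCc2cc(=O)c3c(O)c(O)ccc3o2)cc1` is not yet measured. It differs from compound 3 by methyl in place of nitro on an aromatic carbon; this is the same kind of change as that from compound 1 to compound 2, though there the methyl enters ortho to a large group and here para to a large group. For compound 4 the expected step of a 1.2-fold higher number from compound 3 to compound 4 (0.06 log units; within the scatter) is small, resting on the fact that the same kind of change gave a 1.3-fold higher number from compound 1 to compound 2 (0.10 log units; within the scatter), a step within the scatter. Compound 4 is therefore expected to give about 85000 nM, with a range from 50000 nM to 140000 nM.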

Compound 4, half-maximal cytotoxic concentration: > 100000 nM
Compound 4 ended at the assay's limit; the forecaster's own chance of this, stated with the estimate: 30%; middle value at least 1.1-fold (0.07 log units) from the limit.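

In this assay compound 4 gives > 100000 nM, which is a limit of the assay and not a number. Methyl in place of nitro on an aromatic carbon gives an at least 1.3-fold higher number from compound 3 to compound 4 (0.13 log units; that floor lies within the scatter), and 4-methylphenyl in place of 2-methylphenyl on a saturated chain carbon bound to an amine nitrogen gives an at least 1.9-fold higher number from compound 2 to compound 4 (0.28 log units; that floor lies within the scatter), so neither floor shows a change beyond the scatter. On both cores the methyl-for-nitro change therefore shows no step beyond the scatter, but this does not show that it carries over from one core to the other with the same size: the same change on two cores in this assay, a 1.3-fold higher number (0.10 log units; within the scatter) from compound 1 to compound 2 and an at least 1.3-fold higher number (0.13 log units; that floor lies within the scatter) from compound 3 to compound 4; the limit leaves it open whether they differ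

The compounds shown leave open how the methyl-for-nitro change would read on either core if both members of the pair gave numbers clear of the limit. They also leave open whether an amine or a carboxylic acid in place of the nitro would move the number beyond the scatter on either core.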